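Furan-2-yl for phenyl on the dimethylaminophenyl pyrazoline series

This account rests on a few compounds, and the source may have more. Where it says the series, first, only, none or still open, it means among the compounds named here.

Of the compounds shown here, three of the shared core have been measured in a functional assay on OVCAR cells (Homo sapiens) for cytotoxicity, read by sulforhodamine B assay, with a stated time of 48 h; a lower number here means a stronger inhibitor, a higher number a weaker inhibitor. Compound 1 `CC(=O)N1N=C(c2ccccc2)CC1c1ccc(N(C)C)cc1` gives 12000 nM in this assay, the lowest of the three numbers. Compound 3 `CC(=O)N1N=C(c2ccco2)CC1c1ccccc1[N+](=O)[O-]` gives 28300 nM in this assay, a higher number beyond the scatter, and compound 2 `CC(=O)N1N=C(c2ccc(Br)cc2)CC1c1cccc(Cl)c1Cl` gives 39800 nM in this assay, the highest of the three. Compound 4 `CC(=O)N1N=C(c2ccco2)CC1c1ccc(N(C)C)cc1` is still to be measured in this assay; it differs from compound 1 by furan-2-yl in place of phenyl on a carbon with a double bond to nitrogen. Within the data shown here, no measured pair shows this change on its own, so compound 3 can only be read as a reminder that a furan-2-yl compound has so far sat above compound 1. The step from compound 1 to compound 4 is expected to be small, a 1.3-fold higher number from compound 1 to compound 4 (0.12 log units; within the scatter), if anything toward a higher number. Compound 4 is thus estimated at 16000 nM in this assay, within 6000 nM to 42000 nM.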

Compound 4, half-maximal inhibitory concentration: 14600 nM
The estimate for compound 4 lay 1.1-fold (0.04 log units) above the measured number, within the range that was stated.
By their numbers in this assay, from the lowest: compounds 1, 4, 3 and 2 (each within the scatter of the next, the first and the last beyond it).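

In this assay, this first pair at the carbon with a double bond to nitrogen shows that furan-2-yl can replace phenyl with no change beyond the scatter (a 1.2-fold higher number from compound 1 to compound 4 (0.09 log units; within the scatter)). Here, a five-membered aromatic ring with one oxygen is accepted in place of the six-membered carbon ring, at least on the core of compound 1. Nothing at hand gives a reason for this.

As far as these compounds go, it remains open whether thiophen-2-yl or a pyridine ring would read the same at this carbon. From the compounds shown here alone, it is also open whether this exchange holds when the dimethylaminophenyl group gives way to a nitrophenyl or dichlorophenyl group.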